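Series notes: compound 1 to compound 3, methyl to hydrogen

The source may report more compounds than this note shows. Statements on the series, on what has been measured and on what is new or still open speak of the compounds shown alone.

Measured so far:
compound 1 `Cc1ccc(-c2csc(N3N=C(c4ccc(C)s4)CC3c3ccc(F)cc3)n2)cc1` — a functional assay on A549 cells (Homo sapiens) for antiproliferative activity, read by XTT assay, with a stated time of 24 h; on this read-out higher numbers stand for weaker inhibition and lower numbers for stronger inhibition: > 500 ug/mL
compound 2 `Fc1ccc(C2CC(c3ccc(Cl)s3)=NN2c2nc(-c3ccc(C(F)(F)F)cc3)cs2)cc1` — this assay: > 500 ug/mL

The value of compound 1 in this assay is a limit of the assay, not a number. The value of compound 2 in this assay is likewise a limit. Within the data shown here, compound 1 therefore stands at the limit of > 500 ug/mL in this assay, at which 2 of the 2 values shown sit; no numerical ranking among the measured compounds is possible, and no measured step between them exists.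

Compound 3 `Cc1ccc(C2=NN(c3nc(-c4ccccc4)cs3)C(c3ccc(F)cc3)C2)s1` is not yet measured in this assay. It differs from compound 1 by hydrogen in place of methyl on an aromatic carbon. With both measured values sitting at the limit, the expected step of a number no higher from compound 1 to compound 3 (the limit leaves the size open) is none beyond the scatter, and a reported limit rather than a number is the likeliest outcome. Compound 3 is accordingly expected to give about 500 ug/mL in this assay, with a range from 200 ug/mL to 2000 ug/mL.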

Compound 3, half-maximal inhibitory concentration: > 500 ug/mL
Compound 3: no number, only a limit; the forecaster's own chance of this, stated with the estimate: 80%; the middle value sits exactly at the limit.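

In this assay compound 3 gives > 500 ug/mL, a limit of the assay and not a number. Compound 1 also stands at a limit, so no step can be read between compound 1 and compound 3. The compounds shown leave open whether any change on this core gives a number in this assay.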